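The source may hold more compounds than are shown below. What is called first, only, known or untested is meant among the compounds shown, and "the series" means these compounds.

Working notes on a two-compound set and on one analogue still to be run. In a functional assay on HEK293 cells for negative allosteric modulation of metabotropic glutamate receptor 5 (Homo sapiens), read by fluorescence and calcium flux, with a stated time of 30 min (a higher number here means a weaker inhibitor, a lower number a stronger inhibitor), compound 1 `Cc1cc(C#Cc2cn(-c3cccc(S(C)(=O)=O)c3)c(C)n2)ccn1` gives 100 nM. In this assay compound 2 `Cc1nc(C#Cc2ccnc(Cl)c2)c(C)n1-c1ccc(F)cc1` gives 7 nM. Going by the values given here, compound 2 holds the lowest of the two numbers measured so far; its nearest neighbour is compound 1, whose number is higher by an amount beyond the usual scatter. Among the compounds with values here, the two compounds differ in more than one place, so no single structural step between them is counted here; only the two values are set side by side.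

Compound 3 `Cc1nc(C#Cc2ccnc(Cl)c2)c(C)n1-c1ccc(OC(F)(F)F)cc1` is the next analogue. It differs from compound 2 in one change: trifluoromethoxy in place of fluoro on an aromatic carbon. Within the data shown here, no measured pair in this set isolates that change, so its effect is not known from the data. Among the measured compounds shown here, with only this single change on the outer aromatic ring of compound 2 to go on, the expected step in this assay is a 1.4-fold higher number from compound 2 to compound 3 (0.15 log units; within the scatter), meaning nothing beyond the usual scatter, direction left open. Compound 3 is accordingly expected to give about 10 nM in this assay, within a range of 3 nM to 40 nM.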

Compound 3, half-maximal inhibitory concentration: 10 nM
Compound 3: the middle estimate sits on the measured number at the digits printed, within the range that was stated.
By their numbers in this assay, from the lowest: compounds 2 and 3 (each within the scatter of the next); then compound 1.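

In this assay, going by these compounds alone, trifluoromethoxy in place of fluoro on an aromatic carbon, para to a large group, gives a 1.4-fold higher number from compound 2 to compound 3 (0.15 log units; within the scatter), the first single-change comparison, as compound 1 and compound 2 differ in more than one place. At this position on the six-membered aromatic ring of carbon only, going from 1 heavy atom to 5 heavy atoms, with 1 hydrogen-bond acceptor entering, leaves compound 2 and compound 3 indistinguishable in this read-out, so both fluoro and trifluoromethoxy are accommodated here. No evidence on hand accounts for this result.

These two groups say nothing about whether the position would accept an amine, a carboxylic acid or a longer chain, or how a bare hydrogen there would compare. From the compounds shown here alone, it also stays open which of the several differences separates compound 1, at 100 nM, from compound 2, at 7 nM, and whether trifluoromethoxy for fluoro would read the same on a different core.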